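Methoxy Substitution Across Two Oxadiazole Cores

The source may hold more compounds than are shown below. What is called first, only, known or untested is meant among the compounds shown, and "the series" means these compounds.

The study examines four compounds tested in a functional assay on MDA-MB-453 cells (Homo sapiens) for cytotoxicity, read by MTT assay, with a stated time of 48 h; a lower number here means a stronger inhibitor, a higher number a weaker inhibitor. Compound 1 `N#Cc1ccc(OCc2nnc(-c3ccccc3)o2)cc1F` gives a value recorded only as a limit of the assay, > 50000 nM. Compound 2 `COc1ccc(-c2nnc(COc3ccc(C#N)c(F)c3)o2)cc1` carries methoxy in place of hydrogen on an aromatic carbon and in this assay gives 45500 nM. The measured step of an at least 1.0-fold lower number from compound 1 to compound 2 (0.04 log units; that floor lies within the scatter) is small, and it is bounded by the limit of > 50000 nM in this assay, at which 2 of the 3 values shown sit, so the reading for compound 2 sits close to the edge of what the assay reports. Compound 3 `c1ccc(-c2nnc(COc3ccc(-c4nnco4)cc3)o2)cc1` has a different core from compound 1; the difference between the two cores is not broken down here. In this assay compound 3 is recorded only as a limit, > 50000 nM. Compound 4 `COc1ccc(-c2nnc(COc3ccc(-c4nnco4)cc3)o2)cc1` has not been measured. It differs from compound 3 by methoxy in place of hydrogen on an aromatic carbon, the same change as that from compound 1 to compound 2, at the same place. For compound 4 the step is expected to be a number no higher from compound 3 to compound 4 (the limit leaves the size open), resting on the measured step of an at least 1.0-fold lower number from compound 1 to compound 2 (0.04 log units; that floor lies within the scatter). Compound 4 is therefore expected to give about 50000 nM in this assay, most likely again reported only as a limit, within a range from 25000 nM to 100000 nM.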

Compound 4, half-maximal inhibitory concentration: 36200 nM
For compound 4 the middle estimate is 1.4-fold (0.14 log units) above the measured one; the range from low to high includes it.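

In this assay, the change of phenyl to 4-methoxyphenyl gives an at least 1.3-fold lower number from compound 3 to compound 4 (0.14 log units; that floor lies within the scatter), so the second core, like the first, shows no higher number after the change, though neither step is shown to exceed the usual scatter. Set side by side, the two steps can be compared only loosely: the same change on two cores in this assay, an at least 1.0-fold lower number (0.04 log units; that floor lies within the scatter) from compound 1 to compound 2 and an at least 1.3-fold lower number (0.14 log units; that floor lies within the scatter) from compound 3 to compound 4; the limit leaves it open whether they differ. Each step starts from a compound recorded only as a limit, so the data show that the change can be placed on either core and yield a measured reading, but they do not show that it has the same size on both, or any real effect beyond the scatter on either: the limit of > 50000 nM in this assay, at which 2 of the 4 values shown sit.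

The compounds shown leave open whether another group in place of the methoxy, such as a hydroxyl, an amine, a carboxylic acid or a longer chain like butoxy, would give a reading further from the limit of this assay. They also leave open how the methoxy change would behave on any core other than these two, since a pair of cores is too little to establish a rule for the series.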